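Permeability Outlook for the Trifluoromethylphenyl Analogue, Compound 4

A few compounds are considered here, and "the series" means these few. Any claim that something is new, unique, unknown or untested is made for them only; others in the source may bear on it.

Three measured compounds share one core and sit level in an ADME assay for permeability, using PAMPA, with a stated time of 30 min, at pH 7.4; on this read-out lower numbers stand for lower permeability and higher numbers for higher permeability. Compound 3 `COc1ccc(F)cc1CNCCCNc1ccnc2cc(Cc3ccccc3)ccc12` gives 23 10^-6 cm/s in this assay. Compound 1 `COc1ccc(F)cc1CNCCCNc1ccnc2cc(C3CCCCC3)ccc12` gives 23 10^-6 cm/s, and compound 2 `COc1ccc(F)cc1CNCCCNc1ccnc2cc(Cc3ccc(F)cc3)ccc12` gives 23 10^-6 cm/s. The steps among them, no change at the digits printed from compound 1 to compound 3 (within the scatter), no change at the digits printed from compound 2 to compound 3 (within the scatter) and no change at the digits printed from compound 1 to compound 2 (within the scatter), all stay within the scatter, so the substituent on the aromatic carbon of the fused system has so far left this assay untouched.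

Compound 4 `COc1ccc(F)cc1CNCCCNc1ccnc2cc(-c3ccc(C(F)(F)F)cc3)ccc12` differs from compound 3 as follows: 4-(trifluoromethyl)phenyl in place of benzyl on an aromatic carbon. For the measured compounds named here, no measured step covers this exact change, but every change at that position so far has been flat. Compound 4 is therefore expected to show no change at the digits printed from compound 3 to compound 4 (within the scatter), nothing beyond the scatter. The estimate for compound 4 is 23 10^-6 cm/s, with a range from 12 10^-6 cm/s to 42 10^-6 cm/s.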

Compound 4, apparent permeability: 237 10^-6 cm/s
Beside the measured number, compound 4's estimate is 10-fold (1.01 log units) below it; the whole stated range lies below it.
By their numbers in this assay, from the lowest: compounds 1, 2 and 3 (each within the scatter of the next); then compound 4.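

In this assay this position is not flat after all: 4-(trifluoromethyl)phenyl gives a 10-fold higher number from compound 3 to compound 4 (1.01 log units; beyond the scatter) in place of benzyl, with a 10-fold higher number from compound 2 to compound 4 (1.01 log units; beyond the scatter) in place of 4-fluorobenzyl and a 10-fold higher number from compound 1 to compound 4 (1.01 log units; beyond the scatter) in place of cyclohexyl. The step from benzyl joins two changes, since the linking carbon goes and a trifluoromethyl arrives, so the shown compounds cannot assign the rise to either one. No supporting measurement bears on why the number rises. On these data alone, whether plain phenyl would stand with compound 3 or with compound 4 remains open, and so does the outcome for a phenyl carrying a nitrile or a carboxylic acid in place of the trifluoromethyl.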